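From 2-chlorophenyl to 4-chlorophenyl: working notes on the series

A few compounds are considered here, and "the series" means these few. Any claim that something is new, unique, unknown or untested is made for them only; others in the source may bear on it.

Measured in a functional assay on A549 cells (Homo sapiens) for antiproliferative activity, read by MTT assay, with a stated time of 48 h; a higher number here means a weaker inhibitor, a lower number a stronger inhibitor:
- compound 1 `C/C(=C\CC/C(C)=C/CC[C@@H]1[C@@]2(C)CCC(=O)C(C)(C)[C@H]2CC[C@@]1(C)O)CC/C=C(\C)C(=O)OCc1cn(-c2ccccc2C(F)(F)F)nn1`: > 150000 nM (a limit)
- compound 2 `C/C(=C\CC/C(C)=C/CC[C@@H]1[C@@]2(C)CCC(=O)C(C)(C)[C@H]2CC[C@@]1(C)O)CC/C=C(\C)C(=O)OCc1cn(-c2cccc(Cl)c2)nn1`: 147000 nM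
- compound 3 `C/C(=C\CC/C(C)=C/CC[C@@H]1[C@@]2(C)CCC(=O)C(C)(C)[C@H]2CC[C@@]1(C)O)CC/C=C(\C)C(=O)OCc1cn(-c2ccccc2Cl)nn1`: > 150000 nM (a limit)

Compound 3 has no number, only the limit shown, and the series crowds against (the limit of > 150000 nM in this assay, at which 2 of the 3 values shown sit). The move to compound 4 `C/C(=C\CC/C(C)=C/CC[C@@H]1[C@@]2(C)CCC(=O)C(C)(C)[C@H]2CC[C@@]1(C)O)CC/C=C(\C)C(=O)OCc1cn(-c2ccc(Cl)cc2)nn1` is 4-chlorophenyl in place of 2-chlorophenyl on an aromatic nitrogen.

The closest measured step is an at least 1.0-fold higher number from compound 2 to compound 3 (0.00 log units; that floor lies within the scatter), and the other readable one is an at least 1.0-fold lower number from compound 1 to compound 2 (0.00 log units; that floor lies within the scatter). Each is only a floor within the scatter, so neither gives a real size. From the floor of an at least 1.0-fold higher number from compound 2 to compound 3 (0.00 log units; that floor lies within the scatter), no step beyond the scatter is expected in this assay, and no direction can be expected. The expected change is an at least 1.0-fold lower number from compound 3 to compound 4 (0.02 log units; that floor lies within the scatter), and a report of only a limit would fit that expectation. Compound 4 is estimated at 140000 nM, with an expected range of 85000 nM to 190000 nM.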

Compound 4, half-maximal inhibitory concentration: > 150000 nM
Compound 4 ended at the assay's limit; the forecaster's own chance of this, stated with the estimate: 55%; at least 1.0-fold (0.02 log units) between middle value and limit.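

In this assay compound 4 gives > 150000 nM, which is a limit and not a number. Among these compounds, the steps to compound 4 from compound 3 and from compound 1 cannot be read, as both ends are limits, and the one readable step is an at least 1.0-fold higher number from compound 2 to compound 4 (0.00 log units; that floor lies within the scatter). With 4-chlorophenyl added, the 2-chlorophenyl, 3-chlorophenyl and 4-chlorophenyl compounds are all in hand, and moving the chlorine around this ring gives no step beyond the scatter, with the series still pressed against the top of the assay's range: the limit of > 150000 nM in this assay, at which 3 of the 4 values shown sit.

As far as these compounds go, whether an amine or a carboxylic acid on the phenyl ring would give a value clear of this limit remains open. Any real differences among the chlorophenyl compounds also remain hidden behind the limit.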